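Isopropyl on the carbamoyl nitrogen of compound 2

The compounds below may be only part of what the source reports. "The series", "measured", "known", "first", "only" and "open" are said of these compounds alone.

Compound 1 `NC(=O)N1CCN(C(=S)SCc2cn(Cc3ccccc3F)nn2)CC1`: > 128000 nM
Compound 2 `NC(=O)N1CCN(C(=S)SCc2cn(Cc3ccc(F)cc3)nn2)CC1`: 22100 nM

In a functional assay on MCF7 cells (Homo sapiens) for cytotoxicity, read by MTT assay, with a stated time of 72 h (a lower number here means a stronger inhibitor, a higher number a weaker inhibitor), compound 1 reaches only a limit, > 128000 nM. Compound 2 gives 22100 nM in this assay, and that is the only number shown. The value of compound 1 is a limit (the limit of > 128000 nM in this assay, at which 1 of the 2 values shown sits). Going by the values given here, the one measured step, an at least 5.7-fold lower number from compound 1 to compound 2 (0.76 log units; beyond the scatter), concerns the fluorophenyl alone.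

Compound 3 `CC(C)NC(=O)N1CCN(C(=S)SCc2cn(Cc3ccc(F)cc3)nn2)CC1` differs from compound 2 by isopropyl in place of hydrogen on an amide-type nitrogen. Neither measured compound varies this carbamoyl nitrogen, so the measured step does not bear on the change, and the data give no direction for it. Compound 3 is therefore expected to sit near compound 2 in this assay, with an estimated step of a 1.1-fold lower number from compound 2 to compound 3 (0.04 log units; within the scatter), within the scatter. Compound 3 is estimated at 20000 nM, with a range from 7000 nM to 60000 nM.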

Compound 3, half-maximal inhibitory concentration: 1660 nM
Beside the measured number, compound 3's estimate is 12-fold (1.08 log units) above it, and the stated range ends above it.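

The carbamoyl nitrogen proves to be a position that matters in this assay: isopropyl in place of hydrogen on this amide-type nitrogen gives a 13-fold lower number from compound 2 to compound 3 (1.12 log units; beyond the scatter). Until now the only variation shown lay in the fluorophenyl, so this is the first sign that a second place in the molecule also moves the number, here towards a stronger inhibitor. Nothing given here accounts for the size of this step.

With isopropyl the only group shown on this nitrogen, it remains open whether methyl, a longer chain such as butyl, or a ring such as cyclohexyl would go further or fall back. From the compounds shown here alone, it is also open whether isopropyl would bring a similar change with the 2-fluorophenyl of compound 1, whose value of > 128000 nM is a limit.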